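From Methylsulfanyl to a Benzyl-Selenium Group

This account rests on a few compounds, and the source may have more. Where it says the series, first, only, none or still open, it means among the compounds named here.

Three compounds have been measured in a functional assay on MCF7 cells (Homo sapiens) for cytotoxicity, read by MTT assay, with a stated time of 72 h; a lower number here means that less compound is tolerated, a higher number that more compound is tolerated:
Compound 1, `C[Se]/C(=N\C(=O)c1cccs1)NC(=O)c1cccs1`, gives > 100000 nM, which is a limit of the assay rather than a number.
Compound 2, `C[Se]/C(=N\C(=O)c1ccco1)NC(=O)c1ccco1`, gives > 100000 nM, again only a limit.
Compound 3, `CS/C(=N\C(=O)c1csc([N+](=O)[O-])c1)NC(=O)c1csc([N+](=O)[O-])c1`, gives > 100000 nM, also a limit.

Compound 3 thus stands exactly where every compound shown stands, namely at the limit of > 100000 nM in this assay, at which 3 of the 3 values shown sit, so the numbers cannot set one of these compounds apart from another. Going by the values given here, no step between measured compounds can be read off either, since no two of them differ in just one place.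

Compound 4, `O=C(/N=C(/NC(=O)c1csc([N+](=O)[O-])c1)[Se]Cc1ccccc1)c1csc([N+](=O)[O-])c1`, has not yet been measured. Compared with compound 3 it carries a group of 8 heavy atoms (7 carbon, 1 selenium; one six-membered aromatic ring of carbon only) in place of a group of 2 heavy atoms (1 carbon, 1 sulfur; no ring), on a carbon with a double bond to nitrogen. The values shown give no hint of the direction in which such a change moves the read-out: all three are limits, and none of the differences among the measured compounds resembles this one. The expectation is therefore that compound 4 comes back near the same limit, and a number no higher from compound 3 to compound 4 (the limit leaves the size open) is expected to stay within the usual scatter. For compound 4 the estimate is 100000 nM, in a range from 40000 nM to 300000 nM, with a fair chance that only a limit is reported once more.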

Compound 4, concentration lethal to 50% of the cells: 83800 nM
Estimate against measurement, compound 4: 1.2-fold (0.08 log units) above, within the range that was stated.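

In this assay, compound 4 is the first compound shown to give a real number rather than a limit, so the position on a carbon with a double bond to nitrogen can carry a group with selenium and a six-membered aromatic ring in place of methylsulfanyl and still give a reading within the assay's range. Going by these compounds, this replacement produces an at least 1.1-fold lower number from compound 3 to compound 4 (0.07 log units; that floor lies within the scatter), so the data allow a real drop in the tolerated concentration but do not establish one, and the true size of the step stays unknown. The starting point of that step is not a number, and the same is true of most of the set: the limit of > 100000 nM in this assay, at which 3 of the 4 values shown sit.

The change also swaps two things at once, the sulfur for selenium and the small methyl for a larger group with an aromatic ring, so this single step cannot say which of the two matters. Going by these compounds alone, a benzyl group on sulfur, or a plain methyl on selenium, on the core of compound 4 would separate the two, and an ethyl chain on selenium would show whether a smaller group than the one in compound 4 gives a number at all.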